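The source may report more compounds than this note shows. Statements on the series, on what has been measured and on what is new or still open speak of the compounds shown alone.

Working notes on the series. The shared core is that of compound 1 `O=C1NC(=O)/C(=C/C2=Cc3ccccc3OC2)N1`, which in a functional assay on MOLT-4 cells (Homo sapiens) for antiproliferative activity, read by MTT assay, with a stated time of 72 h (a lower number here means a stronger inhibitor, a higher number a weaker inhibitor), gives 21300 nM. Compound 2 `CCN1C(=O)S/C(=C\C2=Cc3ccccc3OC2)C1=O` carries a different core; in this assay compound 2 gives only > 200000 nM, which is a limit of the assay and not a number (the limit of > 200000 nM in this assay, at which 1 of the 3 values shown sits). Among the compounds with values here, compound 3 `O=C1NC(=O)/C(=C/C2=Cc3cc(Br)ccc3OC2)N1` carries bromo in place of hydrogen on an aromatic carbon and in this assay gives 77500 nM; the step of a 3.6-fold higher number from compound 1 to compound 3 (0.56 log units; beyond the scatter) is the only measured step in the set. Of the two numbers in this assay, compound 3 stands highest, with compound 1 the nearest value.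

Compound 4 `CC1Oc2ccc(Br)cc2C=C1/C=C1\NC(=O)NC1=O` differs from compound 3 by methyl in place of hydrogen on a saturated ring carbon. Within the data shown here, no measured step concerns that position or that group; the one known step concerns bromo on an aromatic carbon and gives no guide for a methyl on the saturated ring carbon. For compound 4 the expected step is therefore no more than the scatter, a 1.0-fold lower number from compound 3 to compound 4 (0.01 log units; within the scatter). The estimate for compound 4 in this assay is 75000 nM, expected to fall between 30000 nM and 190000 nM.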

Compound 4, half-maximal inhibitory concentration: 24800 nM
For compound 4 the middle estimate is 3.0-fold (0.48 log units) above the measured one, and the stated range ends above it.
By their numbers in this assay, from the lowest: compounds 1 and 4 (each within the scatter of the next); then compound 3. At a limit, above all of these: compound 2.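

In this assay, within the data shown here, the saturated ring carbon next to the ring oxygen proves to be a position where a single methyl in place of hydrogen moves the number beyond the scatter: a 3.1-fold lower number from compound 3 to compound 4 (0.49 log units; beyond the scatter) is the first measured step at this position. Among these compounds, its direction is opposite to that of the only earlier step, a 3.6-fold higher number from compound 1 to compound 3 (0.56 log units; beyond the scatter), which concerns bromo on an aromatic carbon. Nothing shown gives a reason for the step at the saturated ring carbon.

From the compounds shown here alone, whether methyl at this carbon gives a step of similar size and direction without the bromo remains open. Also open, going by these compounds, is how this position responds to groups other than methyl, such as an ethyl, a hydroxymethyl or an amine.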